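A few compounds are considered here, and "the series" means these few. Any claim that something is new, unique, unknown or untested is made for them only; others in the source may bear on it.

Measured compounds:
compound 1, `O=C(CCl)Nc1ccc(SCC(=O)Nc2cc(Cl)ccn2)cc1`, with 2800 nM in a functional assay on HeLa cells (Homo sapiens) for antiproliferative activity, read by MTT assay, with a stated time of 48 h; a lower number here means a stronger inhibitor, a higher number a weaker inhibitor
compound 2, `O=C(CCCCl)Nc1ccc(SCC(=O)Nc2ccc(Cl)cn2)cc1`, with > 80000 nM in this assay

Compound 1 is the only one of the two measured compounds that gives a number in this assay. For compound 2 the figure is a limit of the assay and not a number, so its potency is known only from one side. This is the limit described in the limit of > 80000 nM in this assay, at which 1 of the 2 values shown sits, and it leaves the standing of compound 2 open beyond the fact that it is weaker than compound 1 by more than the usual scatter.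

Compound 3, `O=C(CSc1ccc(NC(=O)C(Cl)(Cl)Cl)cc1)Nc1ccc(Cl)cn1`, is the unmeasured compound. It differs from compound 2 in one place: trichloromethyl in place of 3-chloropropyl on a carbonyl carbon. For the measured compounds named here, no measured step of this kind is available, so the expected size of the step in this assay rests on compound 2 alone. Because compound 2 sits at the limit in the limit of > 80000 nM in this assay, at which 1 of the 2 values shown sits, the step from compound 2 to compound 3 is expected to be an at least 2.0-fold lower number from compound 2 to compound 3 (0.30 log units; that floor lies within the scatter), with a real chance that compound 3 also returns only a limit. Compound 3 is estimated at 40000 nM, in a range from 8000 nM to 80000 nM.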

Compound 3, half-maximal inhibitory concentration: > 80000 nM
Compound 3 gave a limit, no number; the forecaster's own chance of this, stated with the estimate: 50%; middle value at least 2.0-fold (0.30 log units) away from the limit.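

In this assay compound 3 gives > 80000 nM, which is a limit and not a number. Compound 2 also gives only a limit, so no step can be read between compound 2 and compound 3: the limit of > 80000 nM in this assay, at which 2 of the 3 values shown sit.

The compounds shown leave open whether trichloromethyl in place of 3-chloropropyl on a carbonyl carbon changes the potency at all.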